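The compounds below may be only part of what the source reports. "The series", "measured", "known", "first", "only" and "open" are said of these compounds alone.

Measured so far:
- compound 1 `O=C(NCCCNC1CCCCC1)c1ccc(C(=O)NCCCNC2CCCCC2)cc1`: 1700 nM
- compound 2 `c1c(CNCCCNC2CCCCC2)cc(CNCCCNC2CCCCC2)cc1CNCCCNC1CCCCC1`: 312 nM
- compound 3 `c1cc(-c2ccc(CNCCCNC3CCCCC3)cc2)ccc1CNCCCNC1CCCCC1`: 67.5 nM

All three values come from an assay on CHO cells for displacement of a labelled ligand from C-X-C chemokine receptor type 4 (Homo sapiens), with a stated time of 40 min; a lower number here means a stronger inhibitor, a higher number a weaker inhibitor. Compound 2 stands second highest of the three numbers. Its nearest neighbour is compound 3, whose lower number puts it beyond the scatter; compound 1 is furthest away, with a higher number, again beyond the scatter. No pair among these three differs in only one place, so no single-point step is available as a reference.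

Compound 4 `CN(C)c1cc(CNCCCNC2CCCCC2)cc(CNCCCNC2CCCCC2)c1` has not yet been measured in this assay. It differs from compound 2 in one place: dimethylamino in place of ((3-(cyclohexylamino)propyl)amino)methyl on an aromatic carbon. The shared core of compound 2 thus keeps two of its three arms and takes a much smaller group in place of the third. Among the measured compounds shown here, no measured pair shows what this change does. The expectation is a step in the direction of a higher number, of moderate size, not certain to reach beyond the scatter. For compound 4 the estimated value is 650 nM, with a range of 200 nM to 2000 nM. The step this estimate means, a 2.1-fold higher number from compound 2 to compound 4 (0.32 log units; beyond the scatter), is expected rather than known.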

Compound 4, half-maximal inhibitory concentration: 119 nM
Compound 4: the middle estimate sits 5.5-fold (0.74 log units) above what was measured, and the stated range ends above it.
By their numbers in this assay, from the lowest: compounds 3 and 4 (each within the scatter of the next); then compound 2; then compound 1.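

In this assay, dimethylamino in place of ((3-(cyclohexylamino)propyl)amino)methyl on this aromatic carbon gives a 2.6-fold lower number from compound 2 to compound 4 (0.42 log units; beyond the scatter) and not a loss. The third arm, with its six-membered carbon ring and two hydrogen-bond donors, is therefore not required to hold the number at the level of compound 2, and a group of only 3 heavy atoms is tolerated at this place on the shared core. Nothing available explains the direction of this step..

The compounds shown leave open whether the lower number comes from losing the arm or from the dimethylamino group itself. A plain hydrogen, an unsubstituted amine or a methoxy group on the same carbon, or a shorter aminoalkyl chain there, would separate these two readings.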